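A methoxy group added to the phenyl of compound 2

A few compounds are considered here, and "the series" means these few. Any claim that something is new, unique, unknown or untested is made for them only; others in the source may bear on it.

The series rests on a shared core that carries a chalcone-type side chain. Going by the values given here, compound 1 `O=C(/C=C/c1cccc(O)c1)c1cccc(-n2cc(-c3ccc(Cl)cc3)[nH]c2=O)c1` is one of the two measured members. In a functional assay on SF-295 cells (Homo sapiens) for inhibition (a lower number here means a stronger inhibitor of growth, a higher number a weaker inhibitor of growth), compound 1 gives 1790 nM. Compound 2 `COc1cc(/C=C/C(=O)c2cccc(-n3cc(-c4ccccc4)[nH]c3=O)c2)cc(OC)c1OC` is the other measured member, and in this assay compound 2 gives 1900 nM. Of the two numbers, that of compound 2 is the one nearer the top, but its nearest neighbour is compound 1 and the two values lie within the usual scatter of each other, so nothing separates them.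

Compound 3 `COc1ccc(-c2cn(-c3cccc(C(=O)/C=C/c4cc(OC)c(OC)c(OC)c4)c3)c(=O)[nH]2)cc1` has not yet been measured. It differs from compound 2 in one place: methoxy in place of hydrogen on an aromatic carbon. Among the compounds with values here, no pair of measured compounds shows what this difference does here, so the data give no direction for it. The estimated step from compound 2 to compound 3 is a 1.1-fold lower number from compound 2 to compound 3 (0.05 log units; within the scatter), which is expected to stay within the scatter. For compound 3 the estimated value is 1700 nM, with a range from 600 nM to 5000 nM.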

Compound 3, concentration for 50% growth inhibition: 4950 nM
Estimate against measurement, compound 3: 2.9-fold (0.46 log units) below; low and high end bracket the measured number.
By their numbers in this assay, from the lowest: compounds 1 and 2 (each within the scatter of the next); then compound 3.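

Going from phenyl to 4-methoxyphenyl gives the first step in this series that can be read, and in this assay it runs a 2.6-fold higher number from compound 2 to compound 3 (0.42 log units; beyond the scatter) toward weaker inhibition of growth, beyond the scatter. The earlier compounds shown here gave no direction for this change, whereas this pair shows that the position on the six-membered aromatic ring of carbon only, para to a large group, does not tolerate methoxy in place of hydrogen without loss, at least with the side chain of compound 2. This rests on a single pair, and nothing measured here accounts for the rise in the number.

As far as these compounds go, it remains open whether the loss is particular to methoxy or would also appear with a hydroxyl group, an amine or a longer ether chain such as ethoxy at the same place. From the compounds shown here alone, it is also open whether methoxy at this position would give a step of similar size and direction on a compound with a different side chain from that of compound 2.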